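The compounds below may be only part of what the source reports. "The series", "measured", "known", "first", "only" and "open" are said of these compounds alone.

Working notes on the series. Among the measured compounds shown here, in a functional assay on K562 cells (Homo sapiens) for cytotoxicity, read by MTT assay, with a stated time of 72 h (a lower number here means a stronger inhibitor, a higher number a weaker inhibitor), compound 1 `Oc1ccc(C2C/C(=N\NC(=S)N3CCOCC3)c3ccc(O)cc3O2)cc1` gives 29400 nM and compound 2 `CCCCNC(=S)N/N=C1\CC(c2ccc(O)cc2)Oc2cc(O)ccc21` gives 17000 nM; these two numbers lie within the scatter of each other, so compound 2 holds no distinct place on the numbers so far. The next compound is compound 3 `Oc1ccc(C2C/C(=N\NC(=S)N3CCCCC3)c3ccc(O)cc3O2)cc1`, which carries piperidin-1-yl in place of butylamino on a thiocarbonyl carbon. For the measured compounds named here, the only measured step at that carbon, butylamino in place of morpholin-4-yl, is a 1.7-fold lower number from compound 1 to compound 2 (0.24 log units; within the scatter) and stays within the scatter. With that single step as the guide, no change beyond the scatter is expected in this assay, in either direction. The expected step is a 1.3-fold higher number from compound 2 to compound 3 (0.11 log units; within the scatter), which is small. For compound 3 the estimated value is 22000 nM, with an expected range from 10000 nM to 45000 nM.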

Compound 3, half-maximal inhibitory concentration: 13700 nM
Compound 3: the middle estimate sits 1.6-fold (0.21 log units) above what was measured, within the range that was stated.
By their numbers in this assay, from the lowest: compounds 3, 2 and 1 (each within the scatter of the next, the first and the last beyond it).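

At the thiocarbonyl carbon in this assay, piperidin-1-yl in place of butylamino gives a 1.2-fold lower number from compound 2 to compound 3 (0.09 log units; within the scatter), so a six-membered ring with no hydrogen-bond donor cannot be told apart from the open chain that carries one. Piperidin-1-yl in place of morpholin-4-yl gives a 2.1-fold lower number from compound 1 to compound 3 (0.33 log units; beyond the scatter), modest, but the first step at this position to lie beyond the scatter, while compound 2 remains within the scatter of both ring compounds. No measurement at hand bears on the reason for either step.

Open, as far as these compounds go, is how 4-methylpiperazin-1-yl or a longer chain such as octylamino would read at this carbon in this assay. From the compounds shown here alone, all three compounds share one core, and whether the step from morpholin-4-yl to piperidin-1-yl carries over to another core stays open.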